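A few compounds are considered here, and "the series" means these few. Any claim that something is new, unique, unknown or untested is made for them only; others in the source may bear on it.

Measured so far in a functional assay on MKN-74 cells (Homo sapiens) for antiproliferative activity, with a stated time of 24 h; a lower number here means a stronger inhibitor, a higher number a weaker inhibitor:
- compound 2 `NC(=O)c1c(NC(=O)c2cccc([N+](=O)[O-])c2)sc2c1CCN(C(=S)Nc1ccccc1Cl)C2` gives 8850 nM
- compound 1 `Cc1ccc(C(=O)Nc2sc3c(c2C(N)=O)CCN(C(=O)Nc2ccccc2Cl)C3)cc1` gives 27600 nM

Compound 2 has the lowest number of the two in this assay; the nearest is compound 1, whose value is beyond the scatter away from it. For the measured compounds named here, compound 1 and compound 2 differ in more than one place, so these two values show only that the pair stands apart, not what any single change contributes.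

Compound 3 `NC(=O)c1c(NC(=O)c2cccc([N+](=O)[O-])c2)sc2c1CCN(C(=O)Nc1ccccc1Cl)C2` is not yet measured. It keeps the nitrobenzamide of compound 2 and differs from it in one place: a group of 10 heavy atoms (7 carbon, 1 nitrogen, 1 oxygen, 1 chlorine; one six-membered aromatic ring of carbon only) in place of a group of 10 heavy atoms (7 carbon, 1 nitrogen, 1 sulfur, 1 chlorine; one six-membered aromatic ring of carbon only), on an amine nitrogen in a ring. Going by the values given here, no pair in the set isolates this change, so its size cannot be read from a measured step. Compound 1, which carries the entering group on the same ring nitrogen, gives a higher number than compound 2, but it also carries a different benzamide. The expectation for compound 3 is therefore a modest rise in number, of a size near the edge of the scatter, and the estimate for compound 3 in this assay is 15000 nM with a range of 5000 nM to 45000 nM. The expected step from compound 2 to compound 3 is a 1.7-fold higher number from compound 2 to compound 3 (0.23 log units; within the scatter).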

Compound 3, half-maximal inhibitory concentration: 22700 nM
For compound 3 the middle estimate is 1.5-fold (0.18 log units) below the measured one; low and high end bracket the measured number.
By their numbers in this assay, from the lowest: compound 2; then compounds 3 and 1 (each within the scatter of the next).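

In this assay, for the compounds shown here, with the nitrobenzamide held constant, exchanging the sulfur-bearing group on the ring amine nitrogen for (2-chlorophenyl)carbamoyl gives a 2.6-fold higher number from compound 2 to compound 3 (0.41 log units; beyond the scatter) and so isolates this change for the first time, with the sulfur-bearing group giving the lower number in this pair. Going by these compounds alone, with (2-chlorophenyl)carbamoyl held on that nitrogen, 3-nitrophenyl in place of 4-methylphenyl on a carbonyl carbon gives a 1.2-fold lower number from compound 1 to compound 3 (0.08 log units; within the scatter) and leaves the two compounds within the scatter of each other, so of the two single changes now isolated, only the one on the ring nitrogen gives a step beyond the scatter. Nothing available speaks to the reason for the step on the ring nitrogen.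

The compounds shown leave open whether the sulfur-bearing group gives a similar step when 4-methylphenyl rather than 3-nitrophenyl sits on the carbonyl carbon. They also leave open how groups of a different kind would read out in this assay, such as an acetyl or a short alkyl chain on the ring nitrogen, or an amine or a carboxylic acid on the benzamide ring.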